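The source may hold more compounds than are shown below. What is called first, only, known or untested is meant among the compounds shown, and "the series" means these compounds.

The compounds measured so far, in an assay on HEK293 cells for inhibition of transient receptor potential cation channel subfamily V member 1 (Homo sapiens), read by FLIPR, at pH 5.5; on this read-out higher numbers stand for weaker inhibition and lower numbers for stronger inhibition:

Compound 1, `CC(C)c1ccc(NC(=O)N2CCN(c3ccc(-c4ccccc4)nn3)CC2)cc1`, gives > 10000 nM, which is a limit of the assay and not a number.
Compound 2, `O=C(Nc1ccc(C(F)(F)F)cc1)N1CCN(c2ccc(-c3ccccc3)nn2)CC1`, gives > 10000 nM, again a limit.
Compound 3, `CC(C)c1ccc(NC(=O)N2CCN(c3nncc4ccccc34)CC2)cc1`, gives > 10000 nM, also a limit.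

All three values sit at the limit of > 10000 nM in this assay, at which 3 of the 3 values shown sit. Compound 4, `O=C(Nc1ccc(C(F)(F)F)cc1)N1CCN(c2nncc3ccccc23)CC1`, is not yet measured in this assay. It differs from compound 3 by trifluoromethyl in place of isopropyl on an aromatic carbon, the same change that separates compound 1 from compound 2, (trifluoromethyl in place of isopropyl on an aromatic carbon), where the step that the two limits leave unreadable from compound 1 to compound 2 was left unreadable by the two limits. The difference between the cores of compound 1 and compound 3 is not broken down here. Because compound 3 gives > 10000 nM, which is a limit, the step that the limit leaves unreadable from compound 3 to compound 4 is expected to be small. Compound 4 is therefore estimated at 15000 nM, most likely reported again only as a limit.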

Compound 4, half-maximal inhibitory concentration: > 10000 nM
Compound 4: no number, only a limit; the forecaster's own chance of this, stated with the estimate: 85%; the middle value does not contradict the limit.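

Compound 3 and compound 4 both give only a limit, so no step can be read between them: the limit of > 10000 nM in this assay, at which 4 of the 4 values shown sit.

The compounds shown leave open whether trifluoromethyl and isopropyl differ at all on either core.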